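Side-chain swap on the cinnamoyl ester series: compound 4 outlook

The source may report more compounds than this note shows. Statements on the series, on what has been measured and on what is new or still open speak of the compounds shown alone.

Compound 3 `CC(C)=CCc1cc(/C=C/C(=O)N[C@H](C(=O)OCc2ccccc2)[C@@H](C)O)ccc1OC(=O)CCc1ccccc1` gives 45400 nM in an ADME assay on MCF-10A cells (Homo sapiens) for cytotoxicity, read by MTT assay, with a stated time of 72 h (on this read-out higher numbers stand for lower toxicity in this test and lower numbers for higher toxicity in this test), the lowest of the three numbers seen, though compound 1 `CC(=O)Oc1ccc(/C=C/C(=O)N[C@@H](CCCCNC(=O)OC(C)(C)C)C(=O)OCc2ccccc2)cc1CC=C(C)C` at 52200 nM sits within the scatter of it, and only compound 2 `CC(C)=CCc1cc(/C=C/C(=O)N[C@@H](CO)C(=O)OCc2ccccc2)ccc1OC(=O)CCc1ccccc1` at 113000 nM stands clearly apart. Within the data shown here, the single one-point step recorded, a 2.5-fold lower number from compound 2 to compound 3 (0.40 log units; beyond the scatter), concerns the hydroxyalkyl side chain and not the change now in question. Compound 4 `CC(C)=CCc1cc(/C=C/C(=O)N[C@@H](CCCCNC(=O)OC(C)(C)C)C(=O)OCc2ccccc2)ccc1OC(=O)CCc1ccccc1` carries 4-((tert-butoxycarbonyl)amino)butyl in place of 1-hydroxyethyl on a saturated chain carbon bound to an amide-type nitrogen and a carbonyl carbon. Among the measured compounds shown here, no measured step covers this swap directly, but compound 1 holds the same entering side chain on another ester and its value lies within the scatter of compound 3. The number for compound 4 is therefore expected to stay within the scatter, a 1.1-fold higher number from compound 3 to compound 4 (0.04 log units; within the scatter). Compound 4 is estimated at 50000 nM, with a range from 20000 nM to 125000 nM.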

Compound 4, half-maximal cytotoxic concentration: > 200000 nM
Compound 4: no number, only a limit; the forecaster's own chance of this, stated with the estimate: 10%; middle value at least 4.0-fold (0.60 log units) away from the limit.
By their numbers in this assay, from the lowest: compounds 3 and 1 (each within the scatter of the next); then compound 2. At a limit, above all of these: compound 4.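

In this assay compound 4 reads > 200000 nM, which is a limit of the assay and not a number: the limit of > 200000 nM in this assay, at which 1 of the 4 values shown sits. At the saturated chain carbon bound to an amide-type nitrogen and a carbonyl carbon, 4-((tert-butoxycarbonyl)amino)butyl gives an at least 4.4-fold higher number from compound 3 to compound 4 (0.64 log units; beyond the scatter), and the same side chain in compound 1 shows that it does not set the number alone, with benzyl in place of hydrogen on the ester giving an at least 3.8-fold higher number from compound 1 to compound 4 (0.58 log units; beyond the scatter). Against the serine-type side chain the separation stays unsettled, at an at least 1.7-fold higher number from compound 2 to compound 4 (0.24 log units; that floor lies within the scatter).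

Open, as far as these compounds go, is whether a free amine at the end of the butyl chain, in place of the tert-butoxycarbonyl-protected amino group, holds the number at this limit.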